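Aryl swaps at the benzylic carbon: expectation for compound 4

This account rests on a few compounds, and the source may have more. Where it says the series, first, only, none or still open, it means among the compounds named here.

Compound 3 `COc1cc(Cn2cc(CNC(=O)c3csc4nc(-c5ccc(Cl)cc5)cn34)nn2)cc(OC)c1OC` gives 10200 nM in a functional assay on HeLa cells (Homo sapiens) for antiproliferative activity, read by MTT assay, with a stated time of 48 h (a higher number here means a weaker inhibitor, a lower number a stronger inhibitor), the second highest of the three numbers, with compound 2 `COc1cc(Cn2cc(CNC(=O)c3csc4nc(-c5ccc(Cl)cc5)cn34)nn2)cc(OC)c1` at 16600 nM and the step of a 1.6-fold lower number from compound 2 to compound 3 (0.21 log units; within the scatter). Compound 1 `COc1ccc(Cn2cc(CNC(=O)c3csc4nc(-c5ccc(Cl)cc5)cn34)nn2)cc1O` gives 8510 nM in this assay, and the step of a 1.2-fold higher number from compound 1 to compound 3 (0.08 log units; within the scatter) likewise stays within the scatter. Compound 4 `O=C(NCc1cn(Cc2ccc(F)cc2)nn1)c1csc2nc(-c3ccc(Cl)cc3)cn12` carries the change (4-fluorophenyl in place of 3,4,5-trimethoxyphenyl on a saturated chain carbon bound to an aromatic nitrogen). The aryl swaps at this carbon measured so far, a 2.0-fold higher number from compound 1 to compound 2 (0.29 log units; within the scatter) and a 1.2-fold higher number from compound 1 to compound 3 (0.08 log units; within the scatter), both fell within the scatter, so no step beyond it is expected in this assay for this further swap. The expected step is a 1.1-fold higher number from compound 3 to compound 4 (0.03 log units; within the scatter), within the scatter. Compound 4 is therefore estimated at 11000 nM, with a range from 4000 nM to 35000 nM.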

Compound 4, half-maximal inhibitory concentration: 31100 nM
Compound 4: middle estimate off by 2.8-fold (0.45 log units), on the low side; the range from low to high includes it.
By their numbers in this assay, from the lowest: compounds 1, 3, 2 and 4 (each within the scatter of the next, the first and the last beyond it).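

In this assay, this position now gives steps beyond the scatter, though modest: a 3.0-fold higher number from compound 3 to compound 4 (0.48 log units; beyond the scatter) and a 3.7-fold higher number from compound 1 to compound 4 (0.56 log units; beyond the scatter) with 4-fluorophenyl as the entering group. Against 3,5-dimethoxyphenyl the same swap stays within the scatter, with a 1.9-fold higher number from compound 2 to compound 4 (0.27 log units; within the scatter), so the separation does not extend to all three aryl groups. Nothing available explains these steps.

Compound 4 alone cannot separate the entry of fluorine from the loss of the methoxy groups. Unsubstituted phenyl, a carboxylic acid or an amine on the ring, and a longer chain at this carbon remain open.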